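The source may hold more compounds than are shown below. What is called first, only, known or untested is meant among the compounds shown, and "the series" means these compounds.

Compound 1 `N#Cc1ccc(Cn2cncc2CNc2ccc(C(=O)Nc3cccc([N+](=O)[O-])c3)c(-c3ccccc3)c2)cc1`: > 10 uM in a functional assay on NIH3T3 cells (Mus musculus); a lower number here means that less compound is needed, a higher number that more compound is needed for the effect
Compound 2 `CC(C)NC(=O)c1ccc(NCc2cncn2Cc2ccc(C#N)cc2)cc1-c1ccccc1`: > 10 uM in this assay
Compound 3 `CSCC[C@H](NC(=O)c1ccc(NCc2cncn2Cc2ccc(C#N)cc2)cc1-c1ccccc1)C(=O)O`: > 10 uM in this assay

In this assay compound 1 gives only a limit, > 10 uM. Compound 2 likewise gives only a limit, > 10 uM. Compound 3 too gives only a limit, > 10 uM. All three sit at the same limit, (the limit of > 10 uM in this assay, at which 3 of the 3 values shown sit), so the steps among them cannot be read: a step that the two limits leave unreadable from compound 1 to compound 2, a step that the two limits leave unreadable from compound 1 to compound 3 and a step that the two limits leave unreadable from compound 2 to compound 3. Compound 3 thus stands at the limit, as do the other two.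

Compound 4 `N#Cc1ccc(Cn2cncc2CNc2ccc(C(=O)Nc3cccc(C#N)c3)c(-c3ccccc3)c2)cc1` differs from compound 3 in one place: 3-cyanophenyl in place of 1-carboxy-3-(methylsulfanyl)propyl on an amide-type nitrogen. Among the measured compounds shown here, no measured step bears readably on this change, since every step measured so far is unreadable. What the three measured compounds show is that three different groups on the amide-type nitrogen, including the 3-nitrophenyl of compound 1, all left the effect beyond the limit. The 3-cyanophenyl of compound 4 resembles that 3-nitrophenyl of compound 1 more closely than it resembles the chain of compound 3. Compound 4 is therefore expected to show a step that the limit leaves unreadable from compound 3 to compound 4 in this assay, that is, no readable gain. The estimate for compound 4 is 15 uM, with a range from 3 uM to 60 uM.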

Compound 4, concentration for half-maximal effect: > 10 uM
Compound 4 gave a limit, no number (the forecaster's own chance of this, stated with the estimate: 70%); the middle value lies beyond the limit too.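

In this assay compound 4 gives only a limit, > 10 uM. Its steps from compound 1, compound 2 and compound 3 cannot be read, since all four compounds share one limit: the limit of > 10 uM in this assay, at which 4 of the 4 values shown sit. The compounds shown leave open which group on the amide-type nitrogen, if any, would give a measurable value.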